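The source may report more compounds than this note shows. Statements on the series, on what has been measured and on what is new or still open speak of the compounds shown alone.

Measured so far in an assay on isolated protein for inhibition of alpha-galactosidase (Coffea arabica), read by spectrophotometry, tested at 1000 uM; on this read-out lower numbers stand for less inhibition and higher numbers for more inhibition at the one concentration tested (going by the name of the read-out):

Compound 1, `O[C@@H]1[C@@H](O)CN[C@H]1c1ccc(-c2ccccc2)cc1`, gives 0.3%.
Compound 2, `O[C@H]1[C@H](CCCc2ccccc2)NC[C@@H]1O`, gives 0%.
Compound 3, `O[C@@H]1[C@@H](O)CN[C@H]1c1ccccc1`, gives 2.6%.

Among these three, compound 2 has the lowest number, but its distances to compound 1 and to compound 3 both lie within the usual scatter of this assay, so no ordering can be read from them. Compound 4, `O[C@H]1[C@H](O)CN[C@@H]1CCCc1ccccc1`, has not yet been measured. Compared with compound 2, (the two compounds have the same atoms and bonds and differ only in configuration as drawn: 3 of 3 stereo elements differ (all stereocentres are inverted: mirror images); a stereocentre at a saturated ring carbon is drawn S in compound 2 and R in compound 4; a stereocentre at a saturated ring carbon is drawn S in compound 2 and R in compound 4; a stereocentre at a saturated ring carbon is drawn S in compound 2 and R in compound 4).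

Within the data shown here, the only measured step between compounds that differ in one place is a number 2.3 percentage points higher from compound 1 to compound 3 (within the scatter). Among the measured compounds shown here, that step swaps a group on an aromatic carbon and says nothing about inverting every stereocentre of the shared core, so no measured step bears on the change from compound 2 to compound 4. With the three measured values all close to zero and to one another, the expected step is a number 1 percentage points higher from compound 2 to compound 4 (within the scatter), which is no step beyond the scatter. Compound 4 is therefore expected to give about 1%, in the range 0% to 8%.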

Compound 4, a percentage reported as inhibition, at one concentration (the size of the read-out at that concentration, not a potency): 0%
Estimate against measurement, compound 4: 1 percentage points above; the measured number falls inside the stated range.
By their numbers in this assay, from the lowest: compounds 2, 4, 1 and 3 (each within the scatter of the next).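

Inverting all three stereocentres of the shared core gives, in this assay, no change at the digits printed from compound 2 to compound 4 (within the scatter). Earlier compounds showed only a change of group, whereas this pair tests configuration alone: the fact that compounds 2 and 4 differ only in the configuration as drawn. Both numbers sit at the bottom of the read-out at the one concentration tested, so the pair cannot show whether configuration would matter for a compound that inhibits this enzyme more strongly.

As far as these compounds go, it remains open whether any compound on this core can give a number beyond the scatter in this assay. Also open, from the compounds shown here alone, are whether the mirror images of compound 1 and compound 3 would read alike, and whether a chain carrying an amine or a carboxylic acid in place of the phenyl would change the number.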